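A Fluoropyridine Swap at the Alkyne Terminus

The compounds below may be only part of what the source reports. "The series", "measured", "known", "first", "only" and "open" are said of these compounds alone.

Compound 1 `C[C@@H](NC(=O)c1ccc(C#Cc2ccccc2F)cn1)C(C)(C)O` stands second highest of three measured values in an ADME assay on HEK293 cells for agonist activity at metabotropic glutamate receptor 5 (Rattus norvegicus), read by fluorescence and calcium flux (on this read-out higher numbers stand for larger maximal responses and lower numbers for smaller maximal responses), where compound 1 gives 29.6%. Its nearest neighbour is compound 3 `C[C@@H](NC(=O)c1ccc(C#Cc2cc(F)ccn2)cn1)C(C)(C)O`, which gives 33%; its furthest is compound 2 `C[C@@H](NC(=O)c1ccc(C#CC2CCCC2)cn1)C(C)(C)O`, which gives 14.8%. The step of a number 3.4 percentage points higher from compound 1 to compound 3 (within the scatter) lies within the scatter, while the steps of a number 14.8 percentage points lower from compound 1 to compound 2 (beyond the scatter) and a number 18.2 percentage points higher from compound 2 to compound 3 (beyond the scatter) are both modest and beyond it.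

Compound 4 `C[C@@H](NC(=O)c1ccc(C#Cc2ncccc2F)cn1)C(C)(C)O` differs from compound 1 in one place: 3-fluoropyridin-2-yl in place of 2-fluorophenyl on a triple-bonded carbon. Going by the values given here, the one measured step that bears on this change is the one in which 4-fluoropyridin-2-yl took the place of 2-fluorophenyl on a triple-bonded carbon, and that step was a number 3.4 percentage points higher from compound 1 to compound 3 (within the scatter). On that basis no step beyond the scatter is expected in this assay from compound 1 to compound 4, and the expected step is a number 0.4 percentage points higher from compound 1 to compound 4 (within the scatter). Compound 4 is estimated to give about 30%, with a range from 18% to 42%.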

Compound 4, largest response reached (reported as efficacy), in percent of the reference or control that the assay uses: 29.2%
Compound 4: middle estimate off by 0.8 percentage points, on the high side; the measured number falls inside the stated range.
By their numbers in this assay, from the lowest: compound 2; then compounds 4, 1 and 3 (each within the scatter of the next).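

In this assay, the 3-fluoropyridin-2-yl group on the triple-bonded carbon cannot be told apart from the 2-fluorophenyl group it replaces (a number 0.4 percentage points lower from compound 1 to compound 4 (within the scatter)), so a second fluoropyridine now shows the same flat result as the first. The two fluoropyridines also cannot be told apart from each other (a number 3.8 percentage points lower from compound 3 to compound 4 (within the scatter)), which shows that the read-out here does not distinguish between these two arrangements of the ring. The cyclopentyl group now stands apart from all three aromatic groups, including the new one (a number 14.4 percentage points higher from compound 2 to compound 4 (beyond the scatter)).

Nothing available explains why these groups give the numbers they do. The compounds shown leave open whether an unsubstituted phenyl, a pyrimidine ring or an open-chain tert-butyl group at this carbon would follow the aromatic groups or the cyclopentyl group.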